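The source may report more compounds than this note shows. Statements on the series, on what has been measured and on what is new or still open speak of the compounds shown alone.

Measured compounds:
- compound 1 `Nc1cc(N)c2nc(-c3ccccc3)c(NCc3ccc(Cl)c(Cl)c3)nc2c1`: 5890 nM
- compound 2 `COc1ccc(CNc2nc3cc(N)cc(N)c3nc2-c2ccccc2)cc1OC`: 33900 nM
- compound 3 `Nc1cc(N)c2nc(-c3ccccc3)c(NCc3ccc(F)cc3)nc2c1`: 4900 nM

All three share one core and differ only in the ring carried on the saturated chain carbon bound to a nitrogen on the aromatic ring. In a functional assay on Hs-578T cells (Homo sapiens) for inhibition, read by sulforhodamine B assay, with a stated time of 48 h (a lower number here means a stronger inhibitor of growth, a higher number a weaker inhibitor of growth), compound 3 gives the lowest number of the three, though compound 1 sits so close that the two cannot be told apart: a 1.2-fold lower number from compound 1 to compound 3 (0.08 log units; within the scatter). Compound 2 stands clearly apart from both, as a 6.9-fold lower number from compound 2 to compound 3 (0.84 log units; beyond the scatter) shows.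

Compound 4 `COc1ccc(CNc2nc3cc(N)cc(N)c3nc2-c2ccccc2)cc1` has not yet been measured. It differs from compound 3 in one place: methoxy in place of fluoro on an aromatic carbon, the change being methoxy in place of fluoro on an aromatic carbon, para to a large group.

Going by the values given here, two measured steps bear on this. Going from two chlorines to two methoxy groups gave a 5.8-fold higher number from compound 1 to compound 2 (0.76 log units; beyond the scatter), and going from two methoxy groups to a single fluorine gave a 6.9-fold lower number from compound 2 to compound 3 (0.84 log units; beyond the scatter). Both say that methoxy on this ring goes with a higher number. Compound 4 carries only one methoxy, so the shift is expected to be smaller than either of those, but still in the same direction.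

Compound 4 is therefore expected to give 12000 nM in this assay, within a range of 5000 nM to 30000 nM, which corresponds to an expected step of a 2.4-fold higher number from compound 3 to compound 4 (0.39 log units; beyond the scatter).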

Compound 4, concentration for 50% growth inhibition: 26900 nM
Compound 4: middle estimate off by 2.2-fold (0.35 log units), on the low side; measured number inside the range.
By their numbers in this assay, from the lowest: compounds 3 and 1 (each within the scatter of the next); then compounds 4 and 2 (each within the scatter of the next).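

A single methoxy on the benzyl ring is enough to raise the number: the step (a 5.5-fold higher number from compound 3 to compound 4 (0.74 log units; beyond the scatter)) lies beyond the scatter, and so does the step from the dichloro compound (a 4.6-fold higher number from compound 1 to compound 4 (0.66 log units; beyond the scatter)). Going by these compounds alone, the earlier compounds could not show this, since their only methoxy example, compound 2, carried two methoxy groups and changed the ring in more than one place at once. Removing one of those two methoxy groups gives no readable change (a 1.3-fold lower number from compound 2 to compound 4 (0.10 log units; within the scatter)), so among these compounds the 4-methoxybenzyl group alone accounts for the higher number, and nothing here explains why.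

A methyl, a hydroxy or an ethoxy group in place of the methoxy would help show whether the oxygen or simply the larger group goes with the higher number, and a bare phenyl ring would give a baseline for all of these changes. A longer chain between the ring and the nitrogen, or an amine on the ring, also remains untested among the compounds shown.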